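The source may hold more compounds than are shown below. What is called first, only, known or untested is meant among the compounds shown, and "the series" means these compounds.

In an ADME assay on the whole organism for pharmacokinetics, with Mus musculus as the target, at a dose of 10 mg/kg by the oral route (on this read-out lower numbers stand for lower exposure and higher numbers for higher exposure at the dose given), the entry for compound 1 `CC1=C(c2cccc(S(C)(=O)=O)c2)C(c2ccc(OC[C@H](C)N3CC[C@@H](C)C3)cc2)Oc2ccc(O)cc21` reads "not determined" (no result reported), compound 2 `CC1=C(c2cccc(O)c2)C(c2ccc(OC[C@H](C)N3CC[C@@H](C)C3)cc2)Oc2ccc(O)cc21` gives 590 ng.h/mL, and compound 3 `CC1=C(c2ccc(F)cc2)C(c2ccc(OC[C@H](C)N3CC[C@@H](C)C3)cc2)Oc2ccc(O)cc21` gives 2000 ng.h/mL, the higher of the two numbers. Compound 4 `CC1=C(c2cccc(F)c2)C(c2ccc(OC[C@H](C)N3CC[C@@H](C)C3)cc2)Oc2ccc(O)cc21` keeps everything else and swaps one group: 3-fluorophenyl in place of 4-fluorophenyl on a double-bonded ring carbon. Among the compounds with values here, one measured step touches this place, a 3.4-fold higher number from compound 2 to compound 3 (0.53 log units; beyond the scatter), but it replaces a hydroxyphenyl with a fluorophenyl. Within the data shown here, no measured pair shows a fluorine changing position, so that step serves only as a loose upper guide. A smaller change is expected here, perhaps slightly downward and probably within the scatter. The estimated change is a 1.3-fold lower number from compound 3 to compound 4 (0.12 log units; within the scatter). For compound 4 the expected value is 1500 ng.h/mL, within an estimated range of 600 ng.h/mL to 3500 ng.h/mL.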

Compound 4, area under the concentration-time curve: 350 ng.h/mL
Beside the measured number, compound 4's estimate is 4.3-fold (0.63 log units) above it; the whole stated range lies above it.
By their numbers in this assay, from the lowest: compounds 4 and 2 (each within the scatter of the next); then compound 3.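

In this assay, the same atoms arranged differently give a 5.7-fold lower number from compound 3 to compound 4 (0.76 log units; beyond the scatter), so exposure depends on whether the phenyl ring carries 4-fluorophenyl or 3-fluorophenyl substitution. Replacing hydroxy with fluoro on an aromatic carbon gives a 1.7-fold lower number from compound 2 to compound 4 (0.23 log units; within the scatter), which lies within the scatter. The earlier rise from compound 2 to compound 3 therefore does not follow from that replacement alone. Nothing available here explains the difference between the two fluorophenyl compounds. Going by these compounds, how a chlorophenyl or an unsubstituted phenyl group would compare at this place remains open.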